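Cyclizing the terminal amine on a long ether chain

A few compounds are considered here, and "the series" means these few. Any claim that something is new, unique, unknown or untested is made for them only; others in the source may bear on it.

Measured so far:
- compound 1, `COc1cc(/C=C/C(=O)Nc2ccccc2)ccc1OCCCCN(C)C`: 1.57
- compound 2, `CCN(CC)CCCCCCCCCCOc1ccc(/C=C/C(=O)Nc2ccccc2)cc1OC`: 1.83

Both compounds were run in a physicochemical assay for lipophilicity, using the shake flask method, measured as octanol-water partition, at pH 7.4; a lower number here means a more polar compound, a higher number a more lipophilic compound. For the measured compounds named here, compound 2 has the higher of the two numbers, but its only neighbour is compound 1, and the gap between them is a number 0.26 log units higher from compound 1 to compound 2 (within the scatter), so the two values cannot be told apart with confidence.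

Compound 3 is `COc1cc(/C=C/C(=O)Nc2ccccc2)ccc1OCCCCCCCCCCN1CCCC1`, not yet measured. It differs from compound 2 in one place: pyrrolidin-1-yl in place of diethylamino on a saturated chain carbon, ten or more bonds along the chain from an oxygen on an aromatic ring. What leaves and what enters have the same count of heavy atoms, donors and acceptors, so the change is a rearrangement of the same pieces into a ring rather than an addition or removal.

Going by the values given here, the one measured step, the change from compound 1 to compound 2, alters both the chain length and the amine at once, and it stayed within the scatter. Among the compounds with values here, no measured pair shows a diethylamino turned into a pyrrolidin-1-yl on its own, so there is no direct precedent. Compound 3 is therefore expected to sit close to compound 2, with the estimated step of a number 0.13 log units lower from compound 2 to compound 3 (within the scatter) not exceeding the scatter. The estimate for compound 3 in this assay is 1.7, expected to fall between 1.3 and 2.2.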

Compound 3, partition coefficient: 1.86
The estimate for compound 3 lay 0.16 log units below the measured number; measured number inside the range.
By their numbers in this assay, from the lowest: compounds 1, 2 and 3 (each within the scatter of the next).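

In this assay, the change from an open diethylamino to a pyrrolidin-1-yl ring, with the long chain left as it was, gives a number 0.03 log units higher from compound 2 to compound 3 (within the scatter), so the two compounds cannot be told apart. This is the first pair shown in which the amine alone differs, whereas the earlier pair differed in both chain and amine. The wider comparison, with chain and amine again differing together, gives a number 0.29 log units higher from compound 1 to compound 3 (within the scatter), so all three compounds lie within the scatter of one another, and no information is available to explain these values.

What the compounds leave open is whether a piperidine or morpholine ring at the end of the same long chain would also stay within the scatter of compound 3, since a ring holding a second hetero atom or one more carbon is a different change from the one seen here. Also open is how a pyrrolidin-1-yl behaves on a shorter chain, as chain length never varies alone among the compounds shown.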